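The compounds below may be only part of what the source reports. "The series", "measured", "known", "first", "only" and "open" are said of these compounds alone.

Measured compounds:
compound 1 `Cc1cccc(Cn2cc(COc3ccc4c(=O)ccoc4c3)nn2)c1`
compound 2 `N#Cc1ccc(Cn2cc(COc3ccc4c(=O)ccoc4c3)nn2)cc1`
compound 3 `O=c1ccoc2cc(OCc3cn(Cc4ccccc4Br)nn3)ccc12`

In a functional assay on HeLa cells (Homo sapiens) for cytotoxicity, read by MTT assay, with a stated time of 48 h (on this read-out lower numbers stand for stronger inhibition and higher numbers for weaker inhibition), compound 1 reaches only the limit > 100000 nM. Compound 2 likewise reaches only the limit > 100000 nM. Compound 3 gives 14500 nM. Compound 2 thus sits at the limit of > 100000 nM in this assay, at which 2 of the 3 values shown sit, together with compound 1, and no number is known for it. Compound 4 `O=c1ccoc2cc(OCc3cn(Cc4cccc(Cl)c4)nn3)ccc12` differs from compound 2 in one place: 3-chlorophenyl in place of 4-cyanophenyl on a saturated chain carbon bound to an aromatic nitrogen. Going by the values given here, the one readable step that bears on this change is an at least 6.8-fold lower number from compound 2 to compound 3 (0.83 log units; beyond the scatter), where 2-bromophenyl entered; the step that the two limits leave unreadable from compound 1 to compound 2 adds nothing readable. A 3-chlorophenyl might follow the 2-bromophenyl of compound 3 or the 3-methylphenyl of compound 1, so only a modest lowering is expected, an at least 2.0-fold lower number from compound 2 to compound 4 (0.30 log units; that floor lies within the scatter). Compound 4 is estimated at 50000 nM, between 10000 nM and 200000 nM.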

Compound 4, half-maximal inhibitory concentration: > 100000 nM
Compound 4: no number, only a limit; the forecaster's own chance of this, stated with the estimate: 50%; at least 2.0-fold (0.30 log units) between middle value and limit.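

In this assay, 3-chlorophenyl in place of 2-bromophenyl gives an at least 6.8-fold higher number from compound 3 to compound 4 (0.83 log units; beyond the scatter), so a chlorine-bearing benzyl group on this chain carbon does not match compound 3. Compound 4 has only a limit, as do compound 1 and compound 2: the limit of > 100000 nM in this assay, at which 3 of the 4 values shown sit. The steps from compound 4 to those two cannot be read, so these three groups cannot be ranked.

On these data alone, compound 3 and compound 4 differ in both the halogen and its place on the ring, so which of the two matters stays open. As far as these compounds go, how an amine or a carboxylic acid in place of the chloro would read also stays open.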